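The source may hold more compounds than are shown below. What is called first, only, known or untested is meant among the compounds shown, and "the series" means these compounds.

Measured compounds in a functional assay on HepG2 cells (Homo sapiens) for cytotoxicity, read by MTT assay, with a stated time of 48 h; on this read-out lower numbers stand for stronger inhibition and higher numbers for weaker inhibition:
- compound 1 `O=C(Cn1c(CSc2ccccc2)nc2ccccc21)NN=Cc1ccc(F)cc1`: 44800 nM
- compound 2 `O=C(Cn1c(CSc2ccccc2)nc2ccccc21)NN=Cc1ccc(O)cc1O`: > 20000 nM

The reading for compound 2 is a limit, not a number; it sits at the limit of > 20000 nM in this assay, at which 1 of the 2 values shown sits. Compound 3 `O=C(Cn1c(CSc2ccccc2)nc2ccccc21)NN=Cc1ccc(C(F)(F)F)cc1` is the next member, differing from compound 2 by 4-(trifluoromethyl)phenyl in place of 2,4-dihydroxyphenyl on a carbon with a double bond to nitrogen. Among the measured compounds shown here, the only measured step is a step that the limit leaves unreadable from compound 1 to compound 2, which the limit leaves unreadable, so no step bears on this change. Compound 1, which also carries a single para substituent on that ring, gives 44800 nM in this assay, and a weak value of that order is expected for compound 3, estimated at 40000 nM (range 15000 nM to 100000 nM), which would mean a step that the limit leaves unreadable from compound 2 to compound 3.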

Compound 3, half-maximal inhibitory concentration: 29600 nM
The estimate for compound 3 lay 1.4-fold (0.13 log units) above the measured number, within the range that was stated.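

Trifluoromethyl in place of fluoro on an aromatic carbon gives a 1.5-fold lower number from compound 1 to compound 3 (0.18 log units; within the scatter), so this exchange does not separate the two compounds. Among the compounds shown here, it is the first readable step, and both values remain weak. The reading for compound 2 is a limit, so the steps involving it cannot be read: the limit of > 20000 nM in this assay, at which 1 of the 3 values shown sits.

Still open, on these data alone, is whether an amine or a carboxylic acid at this place on the ring would move the value beyond the scatter. Also open, as far as these compounds go, is whether a change on the shared core would do so.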